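The source may report more compounds than this note shows. Statements on the series, on what has been measured and on what is new or still open speak of the compounds shown alone.

Compound 2, with the structure `CC(C)(C)OC(=O)N1CCC(O[C@H]2CC[C@H](Oc3ccc(S(C)(=O)=O)cn3)CC2)CC1`, is the starting point here. In a functional assay on isolated protein for agonist activity at Glucose-dependent insulinotropic receptor (Rattus norvegicus), read by HTRF and cAMP accumulation (on this read-out higher numbers stand for larger maximal responses and lower numbers for smaller maximal responses), compound 2 gives 108%, the lowest of the three measured values. Compound 1, `CC(C)(C)OC(=O)N1CCC(O[C@H]2CC[C@H](Oc3ccc(S(C)(=O)=O)cc3)CC2)CC1`, gives 120% in this assay, and compound 3, `CC(C)OC(=O)N1CCC(O[C@H]2CC[C@H](Oc3ccc(S(C)(=O)=O)nc3)CC2)CC1`, gives 125%, so compound 2 sits below both by a margin that is beyond the scatter of the measurement.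

Compound 4 is the unmeasured structure `CC(C)(C)OC(=O)N1CCC(O[C@H]2CC[C@H](Oc3cnc(C#N)cn3)CC2)CC1`. Its difference from compound 2 is 5-cyanopyrazin-2-yl in place of 5-(methylsulfonyl)pyridin-2-yl on an oxygen on a saturated carbon.

Among the compounds with values here, only one measured step touches a change of this kind, the exchange of the aromatic ring attached to the oxygen: a number 12 percentage points lower from compound 1 to compound 2 (beyond the scatter). That step replaced one aromatic ring by another with one more ring nitrogen and cost a modest amount of maximal response. Within the data shown here, the move to compound 4 again adds a ring nitrogen, and also swaps the methylsulfonyl group for a nitrile, a change for which no measured step exists. Compound 3 shows that a ring with the nitrogen placed differently still reaches a high value, so the direction is not fixed by the data. A further modest drop, or no step beyond the scatter, is therefore expected for compound 4: a number 8 percentage points lower from compound 2 to compound 4 (within the scatter). The estimate for compound 4 in this assay is 100%, within a range from 80% to 120%.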

Compound 4, largest response reached (Emax), in percent of the reference or control that the assay uses: 100%
Estimate against measurement, compound 4: no gap at the digits printed; measured number inside the range.
By their numbers in this assay, from the lowest: compounds 4 and 2 (each within the scatter of the next); then compounds 1 and 3 (each within the scatter of the next).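

In this assay, putting 5-cyanopyrazin-2-yl in place of 5-(methylsulfonyl)pyridin-2-yl gives a number 8 percentage points lower from compound 2 to compound 4 (within the scatter) and so leaves the two compounds indistinguishable, even though the methylsulfonyl group is gone and a nitrile has come in. Set against the 4-(methylsulfonyl)phenyl group, the same new group gives a number 20 percentage points lower from compound 1 to compound 4 (beyond the scatter) in this read-out, a modest loss that is clearer than the one seen with the pyridine ring alone, so the group on this oxygen can differ widely in its atoms and a sizeable maximal response remains. No measurement is available here to explain why these exchanges give these numbers.

The aromatic groups shown at this place carry only a methylsulfonyl group or a nitrile, so it remains open how a ring bearing a carboxylic acid, an amide or an amine would behave. On these data alone, it is also open whether the 5-cyanopyrazin-2-yl group would give a similar response with the isopropyl carbamate of compound 3 in place of the tert-butyl carbamate.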